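Opening a ring at the sulfur-linked arm of compound 1

A few compounds are considered here, and "the series" means these few. Any claim that something is new, unique, unknown or untested is made for them only; others in the source may bear on it.

Compound 1 `CCOc1ccc(-c2c(C#N)c(N)nc(SCc3ncc[nH]3)c2C#N)cc1` gives the lowest number of the three measured compounds in an assay on CHO cells for displacement of a labelled ligand from adenosine receptor A1 (Homo sapiens), read by scintillation counting, with a stated time of 90 min (on this read-out higher numbers stand for weaker inhibition and lower numbers for stronger inhibition), with 8.2 nM. Compound 2 `N#Cc1c(N)nc(SCc2ncc[nH]2)c(C#N)c1-c1ccc(OCC2CC2)cc1` gives 235 nM, a change of a 29-fold higher number from compound 1 to compound 2 (1.46 log units; beyond the scatter), and compound 3 `N#Cc1c(N)nc(SCC2=NCCN2)c(C#N)c1-c1ccc(OCC2CC2)cc1` gives 483 nM, a change of a 2.1-fold higher number from compound 2 to compound 3 (0.31 log units; beyond the scatter). Compound 4 `CCOc1ccc(-c2c(C#N)c(N)nc(SCC(=O)NC)c2C#N)cc1` is not yet measured; it differs from compound 1 by methylcarbamoyl in place of 1H-imidazol-2-yl on a saturated chain carbon bound to a sulfur. Within the data shown here, only the step from compound 2 to compound 3 touches the same place, and it was modest; that step kept a ring, whereas here the ring is lost, so a somewhat larger weakening is expected. The estimate for compound 4 in this assay is 35 nM, with a range from 9 nM to 140 nM. This estimate corresponds to an expected step of a 4.3-fold higher number from compound 1 to compound 4 (0.63 log units; beyond the scatter).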

Compound 4, inhibition constant: 104 nM
Compound 4: the middle estimate sits 3.0-fold (0.47 log units) below what was measured; the range from low to high includes it.
By their numbers in this assay, from the lowest: compound 1; then compound 4; then compound 2; then compound 3.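

In this assay, methylcarbamoyl in place of 1H-imidazol-2-yl on the saturated chain carbon bound to a sulfur gives a 13-fold higher number from compound 1 to compound 4 (1.10 log units; beyond the scatter) and shows that this position also responds strongly in the ethoxy series. The entering group has no ring, yet its counts of one hydrogen-bond donor and one acceptor match those of the group that leaves, so matching those counts does not preserve the number of compound 1. Nothing available explains this weakening. As far as these compounds go, whether a 1H-1,2,4-triazol-3-yl ring would stay closer to compound 1 remains open. So does the outcome with a carboxylic acid or a longer chain at this position.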